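The compounds below may be only part of what the source reports. "The series", "measured", "known", "first", "only" and "open" are said of these compounds alone.

Among the compounds with values here, compound 3, the structure `Cc1ccc(-c2cs/c(=N/NC(=O)CSc3ncccn3)n2-c2ccccc2)cc1`, is the only member of this set with a number in a functional assay on C6 cells (Rattus norvegicus) for cytotoxicity, read by MTT assay, with a stated time of 24 h; on this read-out lower numbers stand for stronger inhibition and higher numbers for weaker inhibition: compound 3 gives 85 ug/mL. Two related compounds were included in the same study without a number in this assay: compound 1 with the structure `Cn1cnnc1SCC(=O)N/N=c1/scc(-c2ccc(Br)cc2)n1-c1ccccc1` gives "not determined" (no result reported), and compound 2 with the structure `COc1ccc(-c2cs/c(=N/NC(=O)CSc3nncn3C)n2-c2ccccc2)cc1` gives "not determined" (no result reported), so compound 3 stands alone as the reference point.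

Compound 4, the structure `Cc1ccc(-c2cs/c(=N/NC(=O)CSc3nncn3C)n2-c2ccccc2)cc1`, differs from compound 3 in one place: 4-methyl-4H-1,2,4-triazol-3-yl in place of pyrimidin-2-yl on a sulfur. The arylthiazole and the acylhydrazone arrangement of compound 3 are kept unchanged.

Compound 1 and compound 2 carry the same 4-methyl-4H-1,2,4-triazol-3-yl group as compound 4 yet offer no number, so the effect of this exchange cannot be read from any measured pair. With nothing to anchor a direction, the expected step of no change at the digits printed from compound 3 to compound 4 (within the scatter) is taken to lie within the usual scatter. Compound 4 is therefore estimated at 85 ug/mL, with a plausible range from 40 ug/mL to 180 ug/mL in this assay.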

Compound 4, half-maximal inhibitory concentration: 56 ug/mL
For compound 4 the middle estimate is 1.5-fold (0.18 log units) above the measured one; the measured number falls inside the stated range.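

Read in this assay, the exchange of pyrimidin-2-yl for 4-methyl-4H-1,2,4-triazol-3-yl on a sulfur gives a 1.5-fold lower number from compound 3 to compound 4 (0.18 log units; within the scatter) and is the first measured pair at this position. A five-membered aromatic ring thus takes the place of a six-membered aromatic ring without this assay separating compound 3 from compound 4, so at this read-out the two groups cannot be told apart. No measured property bears on this result, and it stays without an explanation.

The compounds shown leave open whether any group on this sulfur would move the number beyond the scatter, since both groups seen here are aromatic rings of the same heavy-atom count. A carboxylic acid, an open-chain amine or a plain phenyl ring in that place could answer this.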